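A few compounds are considered here, and "the series" means these few. Any claim that something is new, unique, unknown or untested is made for them only; others in the source may bear on it.

Working notes on the series. Compound 1 `O=C(/C=C/c1ccccn1)c1ccc(N2CCN(Cc3cc(C(=O)/C=C/c4ccccn4)ccc3O)CC2)cc1` gives 1230 nM in a functional assay on KB cells (Homo sapiens) for cytotoxicity, with a stated time of 3 days (on this read-out higher numbers stand for weaker inhibition of growth and lower numbers for stronger inhibition of growth), and stands lowest of the two numbers reported so far. Compound 3 `COc1cc(C(=O)/C=C/c2cccnc2)cc(CN2CCN(c3ccc(C(C)=O)cc3)CC2)c1O` gives 13100 nM in this assay, a higher number that lies beyond the scatter; since compound 3 differs from compound 1 in more than one place, the two values are only compared as they stand. Compound 2 `O=C(/C=C/c1cccs1)c1ccc(N2CCN(Cc3cc(C(=O)/C=C/c4cccs4)ccc3O)CC2)cc1` gives > 37000 nM in this assay, which is a limit of the assay and not a number (the limit of > 37000 nM in this assay, at which 1 of the 3 values shown sits).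

Compound 4 `COc1cc(C(=O)/C=C/c2ccccn2)cc(CN2CCN(c3ccc(C(=O)/C=C/c4ccccn4)cc3)CC2)c1O` has not yet been measured in this assay. It differs from compound 1 by methoxy in place of hydrogen on an aromatic carbon of a six-membered aromatic ring of carbon only, ortho to a hydroxy group, on the shared core. Among the measured compounds shown here, no measured pair in the set isolates this change. Compound 3 carries a methoxy of this kind and shows the higher number in this assay, but its other differences from compound 1 leave that comparison open. The expected step from compound 1 to compound 4 is therefore modest, a 1.6-fold higher number from compound 1 to compound 4 (0.21 log units; within the scatter), toward a somewhat higher number, and may not exceed the scatter. Compound 4 is estimated at 2000 nM in this assay, with a range from 700 nM to 6000 nM.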

Compound 4, concentration for 50% growth inhibition: 3980 nM
Compound 4: the middle estimate sits 2.0-fold (0.30 log units) below what was measured; the measured number falls inside the stated range.
By their numbers in this assay, from the lowest: compound 1; then compound 4; then compound 3. At a limit, above all of these: compound 2.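

Working notes, continued. In this assay, among the compounds shown here, methoxy in place of hydrogen on an aromatic carbon, ortho to a hydroxy group, can now be read on its own for the first time, and it gives a 3.2-fold higher number from compound 1 to compound 4 (0.51 log units; beyond the scatter). For the compounds shown here, this position on the shared core is therefore not silent: a group of only 2 heavy atoms, with no ring and no net charge, is enough to move the read-out toward weaker inhibition of growth, and the earlier compounds, which differ in more than one place, could not show this. No measured property in the series bears on this step, so the size of the shift stands as an observation without an explanation.

This single pair cannot show whether the shift belongs to methoxy in particular or to any group at this position, and an ethoxy group, a fluorine atom or an amine there would separate those readings. From the compounds shown here alone, it also remains open whether the same change gives a step of similar size when the pyridin-2-yl groups of compound 1 are replaced by other rings.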